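A few compounds are considered here, and "the series" means these few. Any claim that something is new, unique, unknown or untested is made for them only; others in the source may bear on it.

In an assay for inhibition of acyl-CoA:cholesterol acyltransferase (Oryctolagus cuniculus), using microsomes (on this read-out higher numbers stand for weaker inhibition and lower numbers for stronger inhibition), three compounds have been measured so far:
compound 1 `CCCCCCCCCCC(C)(C)C(=O)Nc1c(C)c([N+](=O)[O-])c(C)c2c1OC(C)(C)C2` gives 36 nM;
compound 2 `CCCCCCCCCCC1(C(=O)Nc2cccc3c2OC(C)(C)C3)CCCC1` gives 500 nM;
compound 3 `CCCCCCCCC(C)(C)C(=O)Nc1c(C)cc(C)c2c1OC(C)(C)C2` gives 140 nM.

Compound 3 stands second highest of these three numbers in this assay. Its nearest neighbour is compound 2, whose number is higher by a margin beyond the scatter, and the furthest is compound 1, whose number is lower, also beyond the scatter.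

Compound 4 `Cc1cc(C)c(NC(=O)C(C)(C)CCCCCCc2ccccc2)c2c1CC(C)(C)O2` differs from compound 3 in a single place: phenyl in place of ethyl on a saturated chain carbon, seven bonds along the chain from a carbonyl carbon. Among the compounds with values here, no measured pair shows this kind of change, so nothing in the data tells its direction. Compound 4 is therefore expected to land close to compound 3, with a step of a 1.1-fold higher number from compound 3 to compound 4 (0.03 log units; within the scatter) that stays within the scatter. Compound 4 is estimated at 150 nM, within a range from 50 nM to 500 nM.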

Compound 4, half-maximal inhibitory concentration: 81 nM
Beside the measured number, compound 4's estimate is 1.9-fold (0.27 log units) above it; the measured number falls inside the stated range.
By their numbers in this assay, from the lowest: compound 1; then compounds 4 and 3 (each within the scatter of the next); then compound 2.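

Within the data shown here, this is the first pair here that differs in only one place. It shows that a saturated chain carbon, seven bonds along the chain from a carbonyl carbon, can carry phenyl instead of ethyl with no change beyond the scatter in this assay: the swap gives a 1.7-fold lower number from compound 3 to compound 4 (0.24 log units; within the scatter). No available measurement explains this result.

Still open, from the compounds shown here alone, is whether a longer chain ending in phenyl, or an amine or a carboxylic acid at this place, would behave alike. Whether phenyl would do the same on the core of compound 1 is also unknown.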